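The source may hold more compounds than are shown below. What is called first, only, known or untested is meant among the compounds shown, and "the series" means these compounds.

Compound 1, whose structure is `CCN1CCc2c(sc(NC(=O)Nc3cccc(Cl)c3Cl)c2C(N)=O)C1`, is one of three ureas built on a shared core and tested in a functional assay (strain AB) with Danio rerio as the target, read by microscopy, with a stated time of 1 h; on this read-out lower numbers stand for an effect already at smaller amounts and higher numbers for an effect only at larger amounts of compound. In this assay compound 1 gives 17400 nM, which is the higher of the two numbers actually reported. Compound 3, with structure `C[N+]1(CC2CCCCC2)CCc2c(sc(NC(=O)Nc3ccc(Cl)cc3)c2C(N)=O)C1`, gives 100 nM, a far lower number, beyond the usual scatter. Compound 2, with structure `CCC1CCc2c(sc(NC(=O)Nc3ccc(Cl)cc3)c2C(N)=O)C1`, reaches only the limit of the assay at > 25000 nM, and so carries no number of its own (the limit of > 25000 nM in this assay, at which 1 of the 3 values shown sits).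

The next compound, compound 4, has structure `CCN1CCc2c(sc(NC(=O)Nc3cccc(C)c3)c2C(N)=O)C1`. It differs from compound 1 in a single place: 3-methylphenyl in place of 2,3-dichlorophenyl on an amide-type nitrogen. The 2,3-dichlorophenyl on the amide-type nitrogen gives way to a 3-methylphenyl, a group of seven carbon atoms without halogen.

Within the data shown here, no measured pair shows the effect of such an exchange. Given how high compound 1 already sits, the step from compound 1 to compound 4 is expected to be small, close to the scatter, with the number perhaps drifting upward rather than downward, as a 1.3-fold higher number from compound 1 to compound 4 (0.10 log units; within the scatter). Compound 4 is therefore expected to give about 22000 nM, somewhere between 7000 nM and 70000 nM.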

Compound 4, half-maximal effective concentration: 13000 nM
Compound 4: the middle estimate sits 1.7-fold (0.23 log units) above what was measured; low and high end bracket the measured number.
By their numbers in this assay, from the lowest: compound 3; then compounds 4 and 1 (each within the scatter of the next). At a limit, above all of these: compound 2.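

In this assay, among these compounds, replacing 2,3-dichlorophenyl with 3-methylphenyl on an amide-type nitrogen gives a 1.3-fold lower number from compound 1 to compound 4 (0.13 log units; within the scatter), the first single-place step that can be read in this set. Among the compounds shown here, this shows that, with the rest of the structure unchanged, this place tolerates the loss of both chlorine atoms and the arrival of a methyl-bearing phenyl without a change beyond the scatter, something the earlier compounds could not show. Nothing at hand explains why the two groups read alike.

The compounds shown leave open how an unsubstituted phenyl, a methoxyphenyl or a phenyl carrying a carboxylic acid would read at this place. They also leave open whether the same exchange would read alike on the core of compound 3, whose number is far lower.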